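The compounds below may be only part of what the source reports. "The series", "measured", "known", "first", "only" and "open" are said of these compounds alone.

In a functional assay on MCF7 cells (Homo sapiens) for cytotoxicity (a higher number here means a weaker inhibitor, a lower number a stronger inhibitor), compound 3 (`C=C/C=C\[C@H](C)[C@H](OC(N)=O)[C@@H](C)[C@H](O)[C@@H](C)C/C(C)=C\[C@H](C)[C@@H](O)[C@@H](C)/C=C\CCc1ccccc1`), whose chain ends in a plain phenyl, gives 560 nM and shares the low end of the numbers with compound 1 (`C=C/C=C\[C@H](C)[C@H](OC(N)=O)[C@@H](C)[C@H](O)[C@@H](C)C/C(C)=C\[C@H](C)[C@@H](O)[C@@H](C)/C=C\CCc1cccc(O)c1C`), which gives 1000 nM in the same test. Compound 2 (`C=C/C=C\[C@H](C)[C@H](OC(N)=O)[C@@H](C)[C@H](O)[C@@H](C)C/C(C)=C\[C@H](C)[C@@H](O)[C@@H](C)/C=C\CCc1cc(F)cc(F)c1`) stands apart at 2000 nM and the step of a 3.6-fold lower number from compound 2 to compound 3 (0.55 log units; beyond the scatter) is the only one of the three that clears the scatter.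

Compound 4 (`C=C/C=C\[C@H](C)[C@H](OC(N)=O)[C@@H](C)[C@H](O)[C@@H](C)C/C(C)=C\[C@H](C)[C@@H](O)[C@@H](C)/C=C\CCc1cccc(O)c1`) has hydroxy in place of hydrogen on an aromatic carbon, meta to a large group (hydroxy in place of hydrogen on an aromatic carbon), which turns phenyl into 3-hydroxyphenyl. Among the compounds with values here, no measured pair isolates this hydroxy alone. The closest evidence is the step of a 1.8-fold lower number from compound 1 to compound 3 (0.25 log units; within the scatter) since compound 1 also carries a hydroxy on its ring, together with a methyl that compound 4 lacks. The step of a 2.0-fold higher number from compound 1 to compound 2 (0.30 log units; within the scatter) likewise stays small, so swapping one substituted ring for the other moved the number little there. The hydroxy is therefore expected to change little, perhaps nudging the number towards that of compound 1. The expected change is a 1.3-fold higher number from compound 3 to compound 4 (0.10 log units; within the scatter) and no move beyond the scatter is anticipated. Compound 4 is estimated at 700 nM with an expected range from 300 nM to 1600 nM in this assay once it is measured.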

Compound 4, half-maximal inhibitory concentration: 390 nM
Compound 4: the middle estimate sits 1.8-fold (0.25 log units) above what was measured, and the stated range covers the measured number.
By their numbers in this assay, from the lowest: compounds 4, 3, 1 and 2 (each within the scatter of the next, the first and the last beyond it).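

In this assay, within the data shown here, the hydroxy on an aromatic carbon, meta to a large group, can be read alone for the first time, and the step is a 1.4-fold lower number from compound 3 to compound 4 (0.16 log units; within the scatter), so the phenyl and 3-hydroxyphenyl ends of the chain cannot be told apart in this test. The ring methyl can now also be read apart from the hydroxy: with the hydroxy kept, hydrogen in place of that methyl gives a 2.6-fold lower number from compound 1 to compound 4 (0.41 log units; beyond the scatter), a modest step that clears the scatter, whereas the earlier comparison of compound 1 with compound 3 changed both groups at once and stayed within it. The exchange of 3,5-difluorophenyl for 3-hydroxyphenyl gives a 5.1-fold lower number from compound 2 to compound 4 (0.71 log units; beyond the scatter), also modest and the widest step among these four compounds, which places the two fluorines, rather than the hydroxy, at the separated end of the series.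

No measurement at hand accounts for any of these steps. From the compounds shown here alone, whether a methoxy or an amine on the same aromatic carbon would read like the hydroxy stays open, as does the effect of a longer chain leading to the ring.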